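Working notes: chloro for methoxy on the aryl amide

A few compounds are considered here, and "the series" means these few. Any claim that something is new, unique, unknown or untested is made for them only; others in the source may bear on it.

Measured so far:
compound 1, `COc1ccc(N2C(=O)COc3ccc(-c4cnc5ccccc5c4)cc32)cc1`: > 40000 nM
compound 2, `COc1ccc(N2C(=O)COc3ccc(-c4cnc(OC)c(NS(=O)(=O)c5ccc(F)cc5)c4)cc32)cc1`: 1220 nM

In a functional assay on HeLa cells (Homo sapiens) for antiproliferative activity, read by MTT assay, with a stated time of 72 h (a lower number here means a stronger inhibitor, a higher number a weaker inhibitor), compound 1 gives only a limit, > 40000 nM, and no number. Among the compounds with values here, compound 2 gives 1220 nM in this assay, but it differs from compound 1 in more than one place, so the pair shows only its two values and no single step. Where compound 1 stands is therefore told by one thing alone: the limit of > 40000 nM in this assay, at which 1 of the 2 values shown sits.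

Compound 3, `O=C1COc2ccc(-c3cnc4ccccc4c3)cc2N1c1ccc(Cl)cc1`, differs from compound 1 in one place: chloro in place of methoxy on an aromatic carbon. Cut one bond further out, the same difference reads 4-methoxyphenyl to 4-chlorophenyl. The shared core of compound 1 and compound 3 is otherwise unchanged. Within the data shown here, no measured step of this kind exists, so the size of the change in this assay is taken as none beyond the scatter, in either direction. The expected step is a number no higher from compound 1 to compound 3 (the limit leaves the size open). Compound 3 is estimated at 40000 nM, with a range from 10000 nM to 150000 nM, and a limit rather than a number is the likelier report.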

Compound 3, half-maximal inhibitory concentration: > 40000 nM
Compound 3: a limit, no number; the forecaster's own chance of this, stated with the estimate: 70%; the middle value lies on the limit itself.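

Compound 1 and compound 3 both stand only as limits in this assay, so no step between them can be read: the limit of > 40000 nM in this assay, at which 2 of the 3 values shown sit.

The compounds shown leave open whether going from 4-methoxyphenyl to 4-chlorophenyl changes the read-out in this assay at all, since neither compound has a number there.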